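From Oxazole Ring to Open-Chain Oxime Ether

The compounds below may be only part of what the source reports. "The series", "measured", "known", "first", "only" and "open" are said of these compounds alone.

Compound 1 `Cc1ncc(-c2ccccc2NCC2=NCCN2)o1`: 110 nM
Compound 2 `Cc1noc(-c2ccccc2NCC2=NCCN2)n1`: 661 nM
Compound 3 `CCO/N=C(\C)c1ccccc1NCC1=NCCN1`: 52.5 nM

In a functional assay for activation of Alpha-1A adrenergic receptor (Homo sapiens), read by calcium flux (on this read-out higher numbers stand for an effect only at larger amounts of compound and lower numbers for an effect already at smaller amounts), compound 1 stands second highest of the three numbers. Its nearest neighbour is compound 3, reached by a 2.1-fold lower number from compound 1 to compound 3 (0.32 log units; beyond the scatter); its furthest is compound 2, reached by a 6.0-fold higher number from compound 1 to compound 2 (0.78 log units; beyond the scatter).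

Compound 4 `CO/N=C/c1ccccc1NCC1=NCCN1` has not yet been measured. Relative to compound 1 the change is a group of 4 heavy atoms (2 carbon, 1 nitrogen, 1 oxygen; no ring) in place of a group of 6 heavy atoms (4 carbon, 1 nitrogen, 1 oxygen; one five-membered aromatic ring with 2 hetero atoms), on an aromatic carbon. The measured step that bears on it most directly is a 2.1-fold lower number from compound 1 to compound 3 (0.32 log units; beyond the scatter), where the same oxazole ring gave way to an open chain, also with a nitrogen and an oxygen, and the number fell modestly. The step of a 13-fold lower number from compound 2 to compound 3 (1.10 log units; beyond the scatter) points the same way, with a larger drop from a different ring. Compound 4 carries a shorter open chain than compound 3, so the outcome is less certain, but a modest lower number than compound 1 is expected, which would be a 1.8-fold lower number from compound 1 to compound 4 (0.26 log units; within the scatter). Compound 4 is therefore estimated at 60 nM, with a range from 25 nM to 150 nM.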

Compound 4, half-maximal effective concentration: 51.3 nM
For compound 4 the middle estimate is 1.2-fold (0.07 log units) above the measured one; the range from low to high includes it.
By their numbers in this assay, from the lowest: compounds 4 and 3 (each within the scatter of the next); then compound 1; then compound 2.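

In this assay, the shorter open chain of compound 4 keeps the whole advantage over the oxazole ring (a 2.1-fold lower number from compound 1 to compound 4 (0.33 log units; beyond the scatter)), so the lower number seen with compound 3 does not depend on the longer chain. Trimming the chain from the group of 6 heavy atoms to the group of 4 leaves the number unchanged within the scatter (a 1.0-fold lower number from compound 3 to compound 4 (0.01 log units; within the scatter)), which shows that this aromatic carbon tolerates both open chains alike. The large gap to the other ring also holds for the shorter chain (a 13-fold lower number from compound 2 to compound 4 (1.11 log units; beyond the scatter)), and among these four compounds both open chains stand lower than both rings, with none going against this.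

As far as these compounds go, whether a longer chain such as a benzyl oxime ether, or an amine at this place, would keep the number remains open. No evidence is at hand on what lies behind these steps.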